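The source may hold more compounds than are shown below. What is called first, only, known or untested is meant among the compounds shown, and "the series" means these compounds.

Measured so far:
compound 1 `O=C(O)CCCCC(CCSC(=O)c1ccccc1)SC(=O)c1ccccc1` gives 86.7%
compound 2 `O=C(CCCCC(S)CCS)Nc1ccc([N+](=O)[O-])cc1` gives 51.2%

In a functional assay on HO8910 cells (Homo sapiens) for inhibition, read by MTT assay, with a stated time of 24 h, tested at 100 ug/mL (a higher number here means more inhibition of growth at the concentration tested, a lower number less inhibition of growth), compound 1 stands highest of the two, and the gap to compound 2 lies beyond the scatter. Compound 3 `O=C(CCCCC(CCSC(=O)c1ccccc1)SC(=O)c1ccccc1)Nc1ccc(Cl)cc1`, not yet measured, keeps the core of compound 1 with this change: (4-chlorophenyl)amino in place of hydroxy on a carbonyl carbon (in words, (4-chlorophenyl)amino in place of hydroxy on a carbonyl carbon). Within the data shown here, no measured pair isolates this change. Compound 2 also has an amide at that carbonyl and gives only 51.2% in this read-out, so a fall beyond the scatter is expected. The expected size is a number 24.7 percentage points lower from compound 1 to compound 3 (beyond the scatter) in this assay as a working figure. Compound 3 is estimated at 62% with an expected range of 38% to 85% in this assay.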

Compound 3, percent growth inhibition at one concentration: "not active" (no number reported)
No number was reported for compound 3; no gap can be computed for the estimate.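

Among these compounds, compound 3 is reported as "not active" in this assay without a number, so no step from compound 1 to compound 3 can be read. The compounds shown leave open how large the change from hydroxy to (4-chlorophenyl)amino on this carbonyl carbon is. No supporting data bear on this result.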